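A few compounds are considered here, and "the series" means these few. Any claim that something is new, unique, unknown or untested is made for them only; others in the source may bear on it.

Among the measured compounds shown here, in a functional assay on MCF7 cells (Homo sapiens) for antiproliferative activity, read by MTT assay, with a stated time of 72 h (a higher number here means a weaker inhibitor, a lower number a stronger inhibitor), compound 1 `O=C1O[C@H]([C@@H](O)Cn2cc(-c3cccc(O)c3)nn2)C(OCc2ccccc2)=C1OCc1ccccc1` gives 51800 nM, while compound 2 `Cc1ccc(S(=O)(=O)NCc2cn(C[C@H](O)[C@H]3OC(=O)C(OCc4ccccc4)=C3OCc3ccccc3)nn2)cc1` gives 6400 nM, the lowest of the two numbers measured so far. For the measured compounds named here, the only measured step, an 8.1-fold lower number from compound 1 to compound 2 (0.91 log units; beyond the scatter), exchanged an aryl group for a sulfonamide-bearing chain. Compound 3 `COc1ccc(-c2cn(C[C@H](O)[C@H]3OC(=O)C(OCc4ccccc4)=C3OCc3ccccc3)nn2)cc1` reverses that kind of change: 4-methoxyphenyl in place of (((4-methylphenyl)sulfonyl)amino)methyl on an aromatic carbon. Compound 1, which also carries an aryl group, gives 51800 nM. On that basis the step of a 4.7-fold higher number from compound 2 to compound 3 (0.67 log units; beyond the scatter) is expected to raise the number beyond the scatter, and compound 3 is estimated at 30000 nM, with a likely range of 8000 nM to 100000 nM.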

Compound 3, half-maximal inhibitory concentration: 99700 nM
Compound 3: middle estimate off by 3.3-fold (0.52 log units), on the low side, within the range that was stated.
By their numbers in this assay, from the lowest: compound 2; then compounds 1 and 3 (each within the scatter of the next).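

Replacing the (((4-methylphenyl)sulfonyl)amino)methyl group with 4-methoxyphenyl on this aromatic carbon gives a 16-fold higher number from compound 2 to compound 3 (1.19 log units; beyond the scatter) in this assay and shows that the change is large in this direction too. The two aryl groups do not separate, with a 1.9-fold higher number from compound 1 to compound 3 (0.28 log units; within the scatter) between 3-hydroxyphenyl and 4-methoxyphenyl, so among these three compounds the lower number stays with the group in compound 2. No measurement here explains why this group differs from the aryl groups. Going by these compounds, it remains open which part of that group matters: a plain aminomethyl group or an amide in its place would help to separate the sulfonyl unit from the chain.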